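A Sulfamoylphenyl in Place of a Benzylamino Group

The compounds below may be only part of what the source reports. "The series", "measured", "known", "first", "only" and "open" are said of these compounds alone.

Of the compounds shown here, three sharing one core have been tested in an ADME assay on Huh-7 cells (Homo sapiens) for cytotoxicity; a lower number here means that less compound is tolerated, a higher number that more compound is tolerated. Compound 1 `CN1CCN(CCCNCc2cn(-c3ccc(C(F)(F)F)cc3)nc2-c2ccc(OC(F)(F)F)cc2)CC1` gives 2300 nM, and compound 3 `CCCN1CCC(CNCc2cn(-c3ccc([N+](=O)[O-])cc3)nc2-c2ccc(C(F)(F)F)cc2)CC1` gives 2300 nM; these two values lie within the usual scatter of each other, so no order between them can be claimed. Compound 2 `Cc1ccccc1CNc1nn(-c2ccc(F)cc2F)cc1CNCCN1CCN(C)CC1` returns only a limit in this assay, > 20000 nM. Among the values shown, that limit, (the limit of > 20000 nM in this assay, at which 1 of the 3 values shown sits), is where compound 2 stands: it is the one compound of the three for which no number is reached.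

Compound 4 `CN1CCN(CCNCc2cn(-c3ccc(F)cc3F)nc2-c2ccc(S(=O)(=O)N(C)C)cc2)CC1` is not yet measured. It differs from compound 2 in one place: 4-(dimethylsulfamoyl)phenyl in place of (2-methylbenzyl)amino on an aromatic carbon. The 2,4-difluorophenyl group and the ((2-(4-methylpiperazin-1-yl)ethyl)amino)methyl group remain as in compound 2. Among the compounds with values here, no measured pair differs in exactly this way, so the size of this step cannot be read from the data; it has to be estimated. The step from compound 2 to compound 4 is expected to be an at least 2.5-fold lower number from compound 2 to compound 4 (0.39 log units; beyond the scatter), that is, a move downward that goes beyond the scatter, though with wide uncertainty. Compound 4 is therefore estimated at 8000 nM, with a range from 2500 nM to 20000 nM.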

Compound 4, half-maximal cytotoxic concentration: > 20000 nM
Compound 4: no number, only a limit; the forecaster's own chance of this, stated with the estimate: 35%; middle value at least 2.5-fold (0.39 log units) from the limit.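

Within the data shown here, compound 2 and compound 4 both end at the same limit of the assay rather than at a number, so no step between them can be read: the limit of > 20000 nM in this assay, at which 2 of the 4 values shown sit.

Still open, as far as these compounds go, is whether, in this assay, 4-(dimethylsulfamoyl)phenyl in place of (2-methylbenzyl)amino changes the tolerated concentration at all, and by how much.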